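A Chain Amine in Place of Methoxy at the Carbonyl

The compounds below may be only part of what the source reports. "The series", "measured", "known", "first", "only" and "open" are said of these compounds alone.

Measured compounds in an assay on L1.2 cells for binding affinity to C-C chemokine receptor type 8 (Homo sapiens); a higher number here means a weaker inhibitor, a lower number a stronger inhibitor:
compound 1 `CCOC(=O)N1CCC(NS(=O)(=O)c2ccc(NC(=O)c3ccccc3)c3ccccc23)CC1` gives 0.17 nM;
compound 2 `CCC(=O)N1CCC(NS(=O)(=O)c2ccc(NC(=O)c3ccccc3C)c3ccccc23)CC1` gives 2.5 nM;
compound 3 `COCC(=O)N1CCC(NS(=O)(=O)c2ccc(NC(=O)c3ccccc3C)c3ccccc23)CC1` gives 15.8 nM.

Compound 3 stands highest of the three numbers; compound 2 sits closest to it, and compound 1 lies furthest away. The step to compound 4 `Cc1ccccc1C(=O)Nc1ccc(S(=O)(=O)NC2CCN(C(=O)CCCCN)CC2)c2ccccc12` is 3-aminopropyl in place of methoxy on a saturated chain carbon bound to a carbonyl carbon. Among the compounds with values here, only one measured step touches the same position, a 6.3-fold higher number from compound 2 to compound 3 (0.80 log units; beyond the scatter), a modest change at a saturated chain carbon bound to a carbonyl carbon. Nothing measured shows what a 3-aminopropyl group does there, so the expectation leans on that one step and on the otherwise shared core. Compound 4 is expected to give 20 nM in this assay, within a range of 5 nM to 80 nM, which means an expected 1.3-fold higher number from compound 3 to compound 4 (0.10 log units; within the scatter).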

Compound 4, inhibition constant: 199 nM
Compound 4: the middle estimate sits 10-fold (1.00 log units) below what was measured, outside the stated range (above it).
By their numbers in this assay, from the lowest: compound 1; then compound 2; then compound 3; then compound 4.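

In this assay, the 3-aminopropyl group brings a 13-fold higher number from compound 3 to compound 4 (1.10 log units; beyond the scatter), and measured against the parent propionyl amide, the chain amine brings an 80-fold higher number from compound 2 to compound 4 (1.90 log units; beyond the scatter). This is a much larger rise than the methoxy change alone, which gave a 6.3-fold higher number from compound 2 to compound 3 (0.80 log units; beyond the scatter), so this position on a saturated chain carbon bound to a carbonyl carbon clearly responds to what is placed there. No evidence given here accounts for the rise.

From the compounds shown here alone, whether the terminal amine or the chain length carries the step remains open. A plain alkyl chain of the same length, a shorter amine chain or a carboxylic acid at the chain end would help separate the two.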